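This account rests on a few compounds, and the source may have more. Where it says the series, first, only, none or still open, it means among the compounds named here.

In an in vivo ADME assay on the whole organism (strain Sprague-Dawley) for pharmacokinetics, with Rattus norvegicus as the target, at a dose of 5 mg/kg by the oral route (a higher number here means that a larger share of the oral dose reaches the circulation, a lower number that a smaller share of the oral dose reaches the circulation), three compounds of one series have been measured. Compound 1 (`Cc1ccc(CNC2(CCC(C)(C)C)C(=O)C(C3=NS(=O)(=O)c4cc(NS(C)(=O)=O)ccc4N3)=C(O)c3ccccc32)cn1`) gives 0%, compound 3 (`COc1ccccc1CNC1(CCC(C)(C)C)C(=O)C(C2=NS(=O)(=O)c3cc(NS(C)(=O)=O)ccc3N2)=C(O)c2ccccc21`) gives 48%, and compound 2 (`CON[C@]1(CCC(C)C)C(=O)C(C2=NS(=O)(=O)c3cc(NS(C)(=O)=O)ccc3N2)=C(O)c2ccccc21`), at 34.1%, stands second highest of the three. Compound 4 (`CC(C)CC[C@@]1(NS(C)(=O)=O)C(=O)C(C2=NS(=O)(=O)c3cc(NS(C)(=O)=O)ccc3N2)=C(O)c2ccccc21`) departs from compound 2 in one place: methylsulfonyl in place of methoxy on an amine nitrogen. For the measured compounds named here, the only measured step, a number 48 percentage points higher from compound 1 to compound 3 (beyond the scatter), exchanges a different group, so it bears on this change only loosely. It shows a large move in one pair but gives no direction here. No clear step beyond the scatter is therefore expected, and the estimated step, a number 6.1 percentage points lower from compound 2 to compound 4 (within the scatter), is uncertain. Compound 4 is expected at 28%, within a range of 8% to 50%.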

Compound 4, oral bioavailability: 0%
Compound 4: the middle estimate sits 28 percentage points above what was measured, outside the stated range (below it).
By their numbers in this assay, from the lowest: compounds 1 and 4 (each within the scatter of the next); then compound 2; then compound 3.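

In this assay, the amine nitrogen on the saturated ring carbon proves sensitive to what it carries: methanesulfonamido in place of methoxyamino gives a number 34.1 percentage points lower from compound 2 to compound 4 (beyond the scatter). The one earlier step changed an aryl group further out, so this is the first large change shown directly on this nitrogen, and it runs downward. Nothing available here explains the loss. The compounds shown leave open whether an acetyl group or a longer alkoxy group on that nitrogen would keep oral bioavailability near that of compound 2.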